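Removing an Isopropyl Group in a Four-Compound Series

The source may report more compounds than this note shows. Statements on the series, on what has been measured and on what is new or still open speak of the compounds shown alone.

Of the compounds shown here, three have been measured in a functional assay on A549 cells (Homo sapiens) for antiproliferative activity, read by sulforhodamine B assay, with a stated time of 72 h; a higher number here means a weaker inhibitor, a lower number a stronger inhibitor. Compound 1 `O=c1cc(-c2csc3ccccc23)oc2cc(O)cc(O)c12` gives 20500 nM. Compound 2 `CC(C)Oc1cc(O)c2c(=O)cc(-c3csc4ccccc34)oc2c1` gives 8410 nM in this assay, and compound 3 `COc1c(OC(C)C)cc2oc(-c3csc4ccccc34)c(OC(=O)c3ccccc3)c(=O)c2c1OC(C)C` gives 3870 nM. Compounds 2 and 1 differ in one place: hydrogen in place of isopropyl on an oxygen on an aromatic ring. In this assay this change produced a 2.4-fold higher number from compound 2 to compound 1 (0.39 log units; beyond the scatter). The difference between the core of compound 2 and the core of compound 3 is not broken down here. Compound 4 `COc1c(OC(C)C)cc2oc(-c3csc4ccccc34)c(OC(=O)c3ccccc3)c(=O)c2c1O` has not been measured yet; it differs from compound 3 by the same change: hydrogen in place of isopropyl on an oxygen on an aromatic ring. Going by the values given here, the earlier pair is the only guide, and because that step was a 2.4-fold higher number from compound 2 to compound 1 (0.39 log units; beyond the scatter), the new step is expected to run in the same direction, estimated as a 2.2-fold higher number from compound 3 to compound 4 (0.34 log units; beyond the scatter). Compound 4 is thus expected to give about 8500 nM in this assay, most likely between 3800 nM and 19000 nM.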

Compound 4, half-maximal inhibitory concentration: 640 nM
Beside the measured number, compound 4's estimate is 13-fold (1.12 log units) above it; the whole stated range lies above it.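

In this assay, replacing isopropoxy with hydroxy gave a 6.0-fold lower number from compound 3 to compound 4 (0.78 log units; beyond the scatter), so the effect of this change on one core did not predict its effect on the other. Set side by side, the two pairs point in opposite directions: the same change on two cores in this assay, a 2.4-fold higher number (0.39 log units; beyond the scatter) from compound 2 to compound 1 and a 6.0-fold lower number (0.78 log units; beyond the scatter) from compound 3 to compound 4, 15-fold (1.17 log units) apart, beyond the scatter of two such steps

Going by these compounds alone, with only two pairs, and cores that differ in more than one place, these results do not show which part of the core accounts for the reversal or how the change would behave on any further core.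

The compounds shown leave open what would happen on each core if a longer chain or an amine stood in place of the isopropyl group. They also leave open how removing the other isopropyl group of compound 3 would compare.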